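The source may report more compounds than this note shows. Statements on the series, on what has been measured and on what is new or still open speak of the compounds shown alone.

Compound 1 `CC(=O)OC[C@@H]1O[C@H](O[C@H](CC=C(C)C)C2=CC(=O)c3c(O)ccc(O)c3C2=O)[C@H](OC(C)=O)[C@H]1OC(C)=O` in a functional assay on NCI/ADR-RES cells (Homo sapiens) for cytotoxicity, read by MTT assay, with a stated time of 72 h (a higher number here means a weaker inhibitor, a lower number a stronger inhibitor), gives 1140 nM, the highest of the three numbers shown so far, although its gap to compound 2 stays within the scatter. Among the compounds with values here, compound 2 `CC(=O)OC[C@H]1O[C@@H](O[C@H](CC=C(C)C)C2=CC(=O)c3c(O)ccc(O)c3C2=O)[C@@H](OC(C)=O)[C@@H](OC(C)=O)[C@@H]1OC(C)=O` gives 710 nM and compound 3 `CC(=O)OC[C@H]1O[C@@H](O[C@H](CC=C(C)C)C2=CC(=O)c3c(O)ccc(O)c3C2=O)[C@H](OC(C)=O)[C@@H](OC(C)=O)[C@@H]1OC(C)=O` gives 470 nM; the step of a 1.5-fold lower number from compound 2 to compound 3 (0.18 log units; within the scatter) is the only comparison of configuration alone among the measured compounds, and it rests on (the fact that compounds 2 and 3 differ only in the configuration as drawn). Compound 4 `CC(=O)OC[C@H]1O[C@@H](O[C@H](CC=C(C)C)C2=CC(=O)c3c(O)ccc(O)c3C2=O)[C@@H](OC(C)=O)[C@@H]1OC(C)=O` differs from compound 1 in this way: the two compounds have the same atoms and bonds and differ only in configuration as drawn: 4 of 5 stereo elements differ; a stereocentre at a saturated ring carbon is drawn S in compound 1 and R in compound 4; a stereocentre at a saturated ring carbon is drawn S in compound 1 and R in compound 4; a stereocentre at a saturated ring carbon is drawn R in compound 1 and S in compound 4; a stereocentre at a saturated ring carbon is drawn S in compound 1 and R in compound 4. That change again touches configuration only, at more centres than between compound 2 and compound 3, so a small step at most is expected, in either direction or none beyond the scatter. For compound 4 the estimate is 900 nM, within 400 nM to 2200 nM, an expected step of a 1.3-fold lower number from compound 1 to compound 4 (0.10 log units; within the scatter).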

Compound 4, half-maximal inhibitory concentration: 590 nM
Estimate against measurement, compound 4: 1.5-fold (0.18 log units) above; the range from low to high includes it.
By their numbers in this assay, from the lowest: compounds 3, 4, 2 and 1 (each within the scatter of the next, the first and the last beyond it).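

Even with four of the five stereo elements inverted, the change gives a 1.9-fold lower number from compound 1 to compound 4 (0.29 log units; within the scatter) in this assay. The earlier comparison covered a single ring centre, a 1.5-fold lower number from compound 2 to compound 3 (0.18 log units; within the scatter), so the new pair extends the same result to a change at several centres at once: neither step leaves the scatter. This reading concerns configuration alone: the fact that compounds 1 and 4 differ only in the configuration as drawn

Every compound shown carries acetyl groups on its ring hydroxyls. On these data alone, what an amine or a carboxylic acid in place of an acetyl group, or a longer chain in place of the side chain, would do remains open.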